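The source may hold more compounds than are shown below. What is called first, only, known or untested is meant among the compounds shown, and "the series" means these compounds.

Of the compounds shown here, three of a shared core have been measured in a functional assay on SW-620 cells (Homo sapiens) for cytotoxicity, read by sulforhodamine B assay, with a stated time of 48 h; on this read-out lower numbers stand for stronger inhibition of growth and higher numbers for weaker inhibition of growth. Compound 1 `Nc1nc(Cl)c2ncn(Cc3ccccc3CCl)c2n1` gives 11800 nM, the highest of the three numbers, which on this read-out means the weakest growth inhibition of the set. Compound 3 `ClCc1ccccc1Cn1cnc2ncnc(Cl)c21` gives 4670 nM, a lower number than compound 1 by a margin beyond the scatter. Compound 2 `ClCc1cccc(Cn2cnc3nc(Cl)nc(Cl)c32)c1` gives 1650 nM, the lowest number of the three and again beyond the scatter away from compound 1.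

The next step is compound 4 `ClCc1ccccc1Cn1cnc2c(Cl)ncnc21`, which is not yet measured. It differs from compound 1 in one place: hydrogen in place of amino on an aromatic carbon. Nothing else in the structure moves.

Within the data shown here, no measured pair shows exactly this exchange, so the expectation rests on compound 3, which also carries no amino group and gives 4670 nM. On that basis a step from compound 1 to compound 4 of about a 2.4-fold lower number from compound 1 to compound 4 (0.37 log units; beyond the scatter) toward lower numbers is expected, of a size beyond the scatter. Compound 4 is therefore estimated at 5000 nM, with a plausible range from 2000 nM to 14000 nM in this assay.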

Compound 4, concentration for total growth inhibition: 5010 nM
The estimate for compound 4 lay 1.0-fold (0.00 log units) below the measured number; the measured number falls inside the stated range.
By their numbers in this assay, from the lowest: compound 2; then compounds 3 and 4 (each within the scatter of the next); then compound 1.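

In this assay, hydrogen in place of amino on the aromatic carbon between two ring nitrogen atoms gives a 2.4-fold lower number from compound 1 to compound 4 (0.37 log units; beyond the scatter). Among these compounds, this is the first direct reading of this change at this position, and it shows that the amino group is not needed for growth inhibition in this pair: without it, inhibition is stronger. Nothing at hand explains why the number moves.

On these data alone, the pair compares only amino and hydrogen at this position, so it remains open how a methyl group, a hydroxyl group or a dimethylamino group would compare with them. As far as these compounds go, it also remains open whether the same exchange would move the number the same way on a different compound of the series, such as compound 2.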